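Ketone side-chain change in a positive allosteric modulator series

The compounds below may be only part of what the source reports. "The series", "measured", "known", "first", "only" and "open" are said of these compounds alone.

Measured so far:
compound 1 `Cc1c(OCCCCOc2ccc(C(=O)O)cc2)ccc(C(=O)CC2CCCC2)c1O` gives 82.6%
compound 2 `Cc1c(OCCCCOCOc2ccc(C(=O)O)cc2)ccc(C(=O)CC2CCCC2)c1O` gives 95.4%
compound 3 `Cc1c(OCCCCOc2cccc(C(=O)O)c2)ccc(C(=O)CC2CCCC2)c1O` gives 80.6%

In an assay on HEK293 cells for positive allosteric modulation of metabotropic glutamate receptor 2 (Rattus norvegicus), read by thallium flux, with a stated time of 2.5 min (a lower number here means a smaller maximal response, a higher number a larger maximal response), compound 1 stands second highest of the three. Compound 3 lies nearest to it, a number 2 percentage points lower from compound 1 to compound 3 (within the scatter); compound 2 lies furthest, a number 12.8 percentage points higher from compound 1 to compound 2 (beyond the scatter). Compound 4 `Cc1c(OCCCCOc2ccc(C(=O)O)cc2)ccc(C(=O)CC(C)C)c1O` differs from compound 1 by isopropyl in place of cyclopentyl on a saturated chain carbon bound to a carbonyl carbon. Among the measured compounds shown here, every measured step concerns the group carried on the oxygen on a saturated carbon; none touches the chain bound to the carbonyl carbon, so no measured step bears directly on this change. With nothing to point in either direction, the expectation is no step beyond the scatter, a number 0.6 percentage points lower from compound 1 to compound 4 (within the scatter). Compound 4 is therefore estimated at 82% in this assay, with a range from 68% to 96%.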

Compound 4, largest response reached (reported as percent of maximum), in percent of the reference or control that the assay uses: 88%
Compound 4: the middle estimate sits 6 percentage points below what was measured, within the range that was stated.
By their numbers in this assay, from the lowest: compounds 3, 1, 4 and 2 (each within the scatter of the next, the first and the last beyond it).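

Swapping cyclopentyl for isopropyl on a saturated chain carbon bound to a carbonyl carbon gives, in this assay, a number 5.4 percentage points higher from compound 1 to compound 4 (within the scatter). Among the compounds shown here, this is the first reading at this position, and for this pair the maximal response holds without the five-membered ring. No available data account for this outcome.

Open, on these data alone, is whether a longer chain, a phenyl ring or an amine at this position would also hold the response. Also open, as far as these compounds go, is whether isopropyl behaves alike alongside the 3-carboxyphenyl group of compound 3 or the (4-carboxyphenoxy)methyl group of compound 2.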